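A few compounds are considered here, and "the series" means these few. Any claim that something is new, unique, unknown or untested is made for them only; others in the source may bear on it.

Compound 1 `CCOC(=O)c1c(-c2cccc(Cl)c2)[nH]c2cc(OC)c(Cl)cc2c1=O` was tested in an ADME assay on Raji cells (Homo sapiens) for cytotoxicity, read by luminescence, with a stated time of 72 h; a higher number here means that more compound is needed for the effect, a lower number that less compound is needed. In this assay compound 1 gives > 21500 nM, which is a limit of the assay and not a number. Compound 2 `CCOC(=O)c1c(-c2cccc(Br)c2)[nH]c2cc(OC)c(Cl)cc2c1=O` carries bromo in place of chloro on an aromatic carbon. In this assay compound 2 gives > 21500 nM, again a limit. Compound 3 `CCOC(=O)c1c(-c2cccc(Cl)c2)[nH]c2cc(OC)c(F)cc2c1=O` differs from compound 1 in its core by fluoro in place of chloro on an aromatic carbon. In this assay compound 3 gives > 21500 nM, also a limit. The steps a step that the two limits leave unreadable from compound 1 to compound 2 and a step that the two limits leave unreadable from compound 1 to compound 3 cannot be sized because all three values sit at the limit of > 21500 nM in this assay, at which 3 of the 3 values shown sit. Compound 4 `CCOC(=O)c1c(-c2cccc(Br)c2)[nH]c2cc(OC)c(F)cc2c1=O` is not yet measured; it carries bromo in place of chloro on an aromatic carbon, the same change at the same place as from compound 1 to compound 2. The step that the limit leaves unreadable from compound 3 to compound 4 is expected to be unreadable as well, resting on a step that the two limits leave unreadable from compound 1 to compound 2. Compound 4 is expected to give 30000 nM in this assay, most likely reported only as a limit.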

Compound 4, half-maximal effective concentration: > 21500 nM
Compound 4 was reported as a limit; the forecaster's own chance of this, stated with the estimate: 85%; the middle value does not contradict the limit.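

The steps from compound 3 and compound 2 to compound 4 cannot be read, because all these results are limits: the limit of > 21500 nM in this assay, at which 4 of the 4 values shown sit.

In this assay the compounds shown leave open how much of each is needed for the effect.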